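Variation at the amide aryl amine in a sulfamate series

The source may report more compounds than this note shows. Statements on the series, on what has been measured and on what is new or still open speak of the compounds shown alone.

Measured so far:
compound 1 `NS(=O)(=O)Oc1ccc2c(c1)CN(C(=O)c1cccc(N3CCCCC3)c1)CC2` — 1%
compound 2 `CCN(Cc1cccc(Br)c1)c1cccc(C(=O)N2CCc3ccc(OS(N)(=O)=O)cc3C2)c1` — 20.9%
compound 3 `CCCN(Cc1ccccc1)c1cccc(C(=O)N2CCc3ccc(OS(N)(=O)=O)cc3C2)c1` — 23.1%

In an assay on HEK293 cells for inhibition of Steryl-sulfatase (Homo sapiens), tested at 0.1 uM (on this read-out lower numbers stand for a weaker effect and higher numbers for a stronger effect at the one concentration tested), compound 3 gives the highest of the three numbers; its nearest neighbour is compound 2, within the scatter, and the gap to compound 1 is beyond the scatter, as a number 22.1 percentage points higher from compound 1 to compound 3 (beyond the scatter) shows. Compound 4 `CCN(Cc1cccnc1)c1cccc(C(=O)N2CCc3ccc(OS(N)(=O)=O)cc3C2)c1` is not yet measured. The change is ethyl((pyridin-3-yl)methyl)amino in place of benzyl(propyl)amino on an aromatic carbon. The step that bears most directly is a number 2.2 percentage points higher from compound 2 to compound 3 (within the scatter), an exchange of one benzyl-bearing amine for another with no change beyond the scatter, while a number 19.9 percentage points higher from compound 1 to compound 2 (beyond the scatter) and a number 22.1 percentage points higher from compound 1 to compound 3 (beyond the scatter) separate the ring-opened amines from piperidin-1-yl. Since compound 4 keeps an open amine, an expected step of a number 4.1 percentage points lower from compound 3 to compound 4 (within the scatter) in this assay, not beyond the scatter, seems reasonable. Compound 4 is therefore estimated at 19%, with a range from 8% to 30%.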

Compound 4, a percentage reported as inhibition, at one concentration (the size of the read-out at that concentration, not a potency): 14.3%
Compound 4: the middle estimate sits 4.7 percentage points above what was measured; low and high end bracket the measured number.
By their numbers in this assay, from the lowest: compound 1; then compounds 4, 2 and 3 (each within the scatter of the next).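

In this assay the exchange of 3-bromophenyl for pyridin-3-yl gives a number 6.6 percentage points lower from compound 2 to compound 4 (within the scatter) and the whole amine exchange gives a number 8.8 percentage points lower from compound 3 to compound 4 (within the scatter), so a hetero atom in this aromatic ring shows no change beyond the scatter. The separation from piperidin-1-yl persists with a number 13.3 percentage points higher from compound 1 to compound 4 (beyond the scatter), and all three open-chain amines now stand apart from that ring. No supporting data bear on these steps.

Open, going by these compounds, is how pyridin-2-yl or pyridin-4-yl would compare with pyridin-3-yl. Also open, on these data alone, is whether a morpholine in place of piperidin-1-yl would stay with compound 1 or move towards the open-chain amines.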